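Compound 2 to compound 4: a carbonyl substituent change

A few compounds are considered here, and "the series" means these few. Any claim that something is new, unique, unknown or untested is made for them only; others in the source may bear on it.

Measured in a toxicity assay on THP-1 cells (Homo sapiens) for inhibition (a higher number here means that more compound is tolerated, a lower number that less compound is tolerated), each value a limit:
compound 1 `COc1ccc(-c2cnc(NC(=O)c3ncc[nH]3)n2C)cc1` > 100000 nM
compound 2 `Cc1ccc(C(=O)Nc2ncc(-c3ccccc3)n2C)cc1` > 50000 nM
compound 3 `COc1ccc(-c2cnc(NC(=O)c3ccc(C)cc3)n2C)cc1` > 100000 nM

Compound 2 stands only at a limit of the assay, > 50000 nM, so it offers no number to start from. Compound 4 `Cn1c(-c2ccccc2)cnc1NC(=O)c1cccc(Cl)c1` carries 3-chlorophenyl in place of 4-methylphenyl on a carbonyl carbon. Among the compounds with values here, two measured steps bear on this change. On the same carbonyl carbon there is a step that the two limits leave unreadable from compound 1 to compound 3. On an aromatic carbon there is a step that the two limits leave unreadable from compound 2 to compound 3. Compound 3 is itself only a limit, > 100000 nM, so neither step gives a size, and no step beyond the scatter is expected in this assay, in either direction. The expected step is a step that the limit leaves unreadable from compound 2 to compound 4. For compound 4 the estimate is 60000 nM, with an expected range of 20000 nM to 150000 nM.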

Compound 4, half-maximal cytotoxic concentration: > 50000 nM
Compound 4 ended at the assay's limit; the forecaster's own chance of this, stated with the estimate: 80%; the middle value is on the limit's open side.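

In this assay compound 4 gives > 50000 nM, which is a limit. Within the data shown here, compound 2 also stands at a limit, so no step between compound 2 and compound 4 can be read. The compounds shown leave open at what concentration, if any, any of the four becomes toxic to these cells.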